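Biaryl to diaryl ether on a shared thiazepinone core

This account rests on a few compounds, and the source may have more. Where it says the series, first, only, none or still open, it means among the compounds named here.

Measured so far:
compound 1, `COc1ccc(C2SC(C)C(=O)Nc3c2c(C)nn3-c2ccccc2C)c(OC)c1`: 10500 nM
compound 2, `COc1cccc(-c2ccc([C@H]3S[C@@H](C)C(=O)Nc4c3c(C)nn4-c3ccccc3C)cc2)c1`: 1800 nM

In an assay on isolated protein for agonist activity at Bile acid receptor (Homo sapiens), read by AlphaScreen, with a stated time of 30 min (on this read-out lower numbers stand for an effect already at smaller amounts and higher numbers for an effect only at larger amounts of compound), compound 2 gives 1800 nM, the lowest of the two numbers recorded, while compound 1 gives 10500 nM, a gap beyond the usual scatter. Compound 3, `COc1cccc(Oc2ccc([C@H]3S[C@@H](C)C(=O)Nc4c3c(C)nn4-c3ccccc3C)cc2)c1`, has not yet been measured. It differs from compound 2 by one change: 3-methoxyphenoxy in place of 3-methoxyphenyl on an aromatic carbon. Among the compounds with values here, no measured pair shows what such a change does here, so the size of the step is uncertain. A modest step in this assay is expected, most likely toward a somewhat higher number, with no change beyond the scatter remaining plausible; for compound 3 the expected step is a 1.6-fold higher number from compound 2 to compound 3 (0.19 log units; within the scatter). Compound 3 is thus estimated at 2800 nM, within a range of 900 nM to 9000 nM.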

Compound 3, half-maximal effective concentration: 1700 nM
Compound 3: middle estimate off by 1.6-fold (0.22 log units), on the high side; measured number inside the range.
By their numbers in this assay, from the lowest: compounds 3 and 2 (each within the scatter of the next); then compound 1.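

Replacing 3-methoxyphenyl with 3-methoxyphenoxy on this aromatic carbon gives a 1.1-fold lower number from compound 2 to compound 3 (0.02 log units; within the scatter) in this assay, so the two compounds cannot be told apart. At this position, then, the ring can carry either group with no difference beyond the scatter, even though the new group adds one oxygen and one hydrogen-bond acceptor. Nothing available explains why the two groups read alike. Still open, going by these compounds, is whether an amine linking the ring at this carbon would read the same, and whether a carboxylic acid in place of the methoxy group would shift the number.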